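A few compounds are considered here, and "the series" means these few. Any claim that something is new, unique, unknown or untested is made for them only; others in the source may bear on it.

Compound 1 `CCn1c(C(=O)NCC(=O)OC)ccc1C(CC)(CC)c1ccc(OCS(=O)(=O)c2ccccc2)c(C)c1`: in a functional assay on PC-3 cells (Homo sapiens) for antiproliferative activity, read by MTT assay, with a stated time of 24 h (a lower number here means a stronger inhibitor, a higher number a weaker inhibitor), compound 1 gives > 50000 nM, a limit of the assay rather than a number.
Compound 2 `CCn1c(C(=O)N[C@H](C)C(=O)OC)ccc1C(CC)(CC)c1ccc(OCS(=O)(=O)c2ccccc2)c(C)c1`: compound 2 gives > 50000 nM, likewise a limit.
Compound 3 `CCn1c(C(=O)N[C@@H](C)CO)ccc1C(CC)(CC)c1ccc(OCS(=O)(=O)c2ccccc2)c(C)c1`: compound 3 gives 9520 nM.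

Compound 2 thus stands only at a limit, sharing the limit of > 50000 nM in this assay, at which 2 of the 3 values shown sit, with compound 1. Compound 4 `CCn1c(C(=O)N[C@H](CO)CCO)ccc1C(CC)(CC)c1ccc(OCS(=O)(=O)c2ccccc2)c(C)c1` differs from compound 2 in one place: 3-hydroxy-1-(hydroxymethyl)propyl in place of 1-(methoxycarbonyl)ethyl on an amide-type nitrogen. The step that bears on this is an at least 5.2-fold lower number from compound 2 to compound 3 (0.72 log units; beyond the scatter), where the same ester-bearing group left and a hydroxyl-bearing group entered; an at least 5.2-fold lower number from compound 1 to compound 3 (0.72 log units; beyond the scatter) points the same way, while a step that the two limits leave unreadable from compound 1 to compound 2 stays unreadable. A lowering of similar size is therefore expected, an at least 4.1-fold lower number from compound 2 to compound 4 (0.61 log units; beyond the scatter). Compound 4 is estimated at 12000 nM, with a range from 4000 nM to 50000 nM.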

Compound 4, half-maximal inhibitory concentration: 12100 nM
For compound 4 the middle estimate is 1.0-fold (0.00 log units) below the measured one; the range from low to high includes it.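

Within the data shown here, the ester-bearing group gives way to 3-hydroxy-1-(hydroxymethyl)propyl on the amide-type nitrogen, and this brings an at least 4.1-fold lower number from compound 2 to compound 4 (0.61 log units; beyond the scatter) and an at least 4.1-fold lower number from compound 1 to compound 4 (0.61 log units; beyond the scatter), so compound 3 is no longer the only hydroxyl-bearing compound with a measurable value. The added hydroxymethyl brings no readable gain, with a 1.3-fold higher number from compound 3 to compound 4 (0.10 log units; within the scatter). Both steps from the esters are only minimum sizes, because compound 1 and compound 2 stand at a limit: the limit of > 50000 nM in this assay, at which 2 of the 4 values shown sit.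

As far as these compounds go, whether an amine, a carboxylic acid or a longer chain ending in hydroxyl on this nitrogen would give a lower number stays open. So does whether a plain alkyl group without oxygen would do as well.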